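Swapping chloro for hydroxy on two related cores

A few compounds are considered here, and "the series" means these few. Any claim that something is new, unique, unknown or untested is made for them only; others in the source may bear on it.

Measured so far:
compound 1 `O=C(CSc1nc(-c2ccc(Cl)cc2)c(C(=O)O)c(=O)[nH]1)Nn1c(COc2ccc(Cl)cc2Cl)nc2ccccc2c1=O` gives 51.9%
compound 2 `O=C(CSc1nc(-c2ccc(O)cc2)c(C(=O)O)c(=O)[nH]1)Nn1c(COc2ccc(Cl)cc2Cl)nc2ccccc2c1=O` gives 32.7%
compound 3 `N#Cc1c(Nc2ccccc2)nc(SCC(=O)Nn2c(COc3ccc(Cl)cc3Cl)nc3ccccc3c2=O)nc1-c1ccc(Cl)cc1` gives 36.5%

All three were tested in a functional assay on the whole organism (strain albino) for inhibition, with Rattus norvegicus as the target, read by paw edema, with stated times of 1 h and 0.5 h, at a dose of 100 mg/kg by the oral route; on this read-out lower numbers stand for less inhibition and higher numbers for more inhibition at the one dose given (going by the name of the read-out). Compound 1 and compound 2 share a core and differ in one place, (hydroxy in place of chloro on an aromatic carbon). That change made a step of a number 19.2 percentage points lower from compound 1 to compound 2 (beyond the scatter). Compound 3 carries a different core; how the two cores differ is not broken down here. Compound 3 stands closest to compound 2 in this assay, and the gap between those two is within the usual scatter of repeated measurements.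

Compound 4 `N#Cc1c(Nc2ccccc2)nc(SCC(=O)Nn2c(COc3ccc(Cl)cc3Cl)nc3ccccc3c2=O)nc1-c1ccc(O)cc1` is not yet measured. It differs from compound 3 by hydroxy in place of chloro on an aromatic carbon, the same change as from compound 1 to compound 2, at a place described in the same words. Among the measured compounds shown here, the one measured example of this change lowered inhibition by a modest amount, so a downward step of similar size is expected here, resting on a number 19.2 percentage points lower from compound 1 to compound 2 (beyond the scatter) as the only guide. The expected step is a number 17.5 percentage points lower from compound 3 to compound 4 (beyond the scatter), and compound 4 is estimated at 19%, with a likely range from 8% to 32%.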

Compound 4, a percentage reported as inhibition, in the whole organism at one dose (the size of the read-out at that dose, not a potency): 90.4%
Estimate against measurement, compound 4: 71.4 percentage points below; the measured number lies above the stated range.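

On the core of compound 3, hydroxy in place of chloro gave a number 53.9 percentage points higher from compound 3 to compound 4 (beyond the scatter) in this assay, so the change did not carry over from the core of compound 1 in either direction or size: the same change on two cores in this assay, a number 19.2 percentage points lower (beyond the scatter) from compound 1 to compound 2 and a number 53.9 percentage points higher (beyond the scatter) from compound 3 to compound 4, 73.1 percentage points apart, beyond the scatter of two such steps

For these two pairs, then, the outcome of swapping 4-chlorophenyl for 4-hydroxyphenyl depends on the core that carries it, and the step measured on one core was a poor guide to the step on the other. This does not show why the two cores respond differently, and two pairs give no rule for predicting the step on any further core.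

The compounds shown leave open whether the rise on the core of compound 3 is specific to hydroxy or would also appear with another group in the same place, such as methoxy or fluoro. They also leave open which of the differences between the two cores sets the direction of the step.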